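The source may report more compounds than this note shows. Statements on the series, on what has been measured and on what is new or still open speak of the compounds shown alone.

Series notes, cytotoxicity.

The shared core carries two substituents on ring nitrogens, and the three measured compounds vary the groups on the saturated chain carbon bound to the amide-type nitrogen. Compound 1 `O=C1N(Cc2ccc(Cl)cc2Cl)c2cccn2S(=O)(=O)N1Cc1ccccc1` gives 218000 nM in an ADME assay on MT4 cells (Homo sapiens) for cytotoxicity, read by MTT assay, with a stated time of 5 days; on this read-out lower numbers stand for higher toxicity in this test and higher numbers for lower toxicity in this test. Among the measured compounds shown here, compound 3 `O=C1N(Cc2cccc(Cl)c2)c2cccn2S(=O)(=O)N1Cc1ccccc1` gives 196000 nM in this assay, and the change a 1.1-fold lower number from compound 1 to compound 3 (0.05 log units; within the scatter) is the only single-point step among the measured compounds. For compound 2 `O=C1N(Cc2ccccc2)c2cccn2S(=O)(=O)N1Cc1cccc(F)c1` the read-out in this assay is a limit of the assay, > 288000 nM, and no number is known; this is the case covered by the limit of > 288000 nM in this assay, at which 1 of the 3 values shown sits.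

Compound 4 `N#CCN1C(=O)N(Cc2cccc(F)c2)S(=O)(=O)n2cccc21` differs from compound 2 by cyano in place of phenyl on a saturated chain carbon bound to an amide-type nitrogen in a ring. For the measured compounds named here, no measured step alters this position in the same way, and the one step available lies within the scatter, so no shift beyond the scatter is expected in this assay for compound 4. Compound 4 is therefore expected near the limit, at 280000 nM with a range from 150000 nM to 600000 nM, which corresponds to an expected step of an at least 1.0-fold lower number from compound 2 to compound 4 (0.01 log units; that floor lies within the scatter).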

Compound 4, half-maximal cytotoxic concentration: 172000 nM
Compound 4: middle estimate off by 1.6-fold (0.21 log units), on the high side, within the range that was stated.
By their numbers in this assay, from the lowest: compounds 4, 3 and 1 (each within the scatter of the next). At a limit, above all of these: compound 2.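

The phenyl at this position is not required for a high number in this assay, since the earlier step only exchanged one chlorinated phenyl for another, whereas here cyano takes the place of the whole ring on a saturated chain carbon bound to an amide-type nitrogen in a ring. Read as benzyl to cyanomethyl, the change gives an at least 1.6-fold lower number from compound 2 to compound 4 (0.22 log units; that floor lies within the scatter) and so shows no shift beyond the scatter, but this is only a floor and the full size of the step stays unknown. Compound 2 is held at a limit of the assay and has no number: the limit of > 288000 nM in this assay, at which 1 of the 4 values shown sits.

Open, from the compounds shown here alone, is how an amine, a carboxylic acid or a longer chain would read at this place. Also open, going by these compounds, is whether the step from phenyl to cyano would look the same on a parent compound with a measured number.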